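Replacing the oxazole on the lactam ring of compound 1

The source may hold more compounds than are shown below. What is called first, only, known or untested is meant among the compounds shown, and "the series" means these compounds.

Measured compounds:
- compound 1 `O=C1CC(c2cnco2)CN1c1cnn2c1CN(C(=O)Nc1cc(F)c(F)c(F)c1)C(C1CC1)C2`: 139000 nM
- compound 2 `O=C(Nc1cc(F)c(F)c(F)c1)N1Cc2c(-c3ccc(F)cc3F)cnn2CC1C1CC1`: 32100 nM
- compound 3 `CC1(C)CC(=O)N(c2cnn3c2CN(C(=O)Nc2cc(F)c(F)c(F)c2)C(C2CC2)C3)C1`: 115000 nM

In a toxicity assay on HepG2 2.2.15 cells (Homo sapiens) for cytotoxicity, read by CellTiter-Glo (a lower number here means that less compound is tolerated, a higher number that more compound is tolerated), compound 1 gives 139000 nM, the top of the three numbers, though a 1.2-fold lower number from compound 1 to compound 3 (0.08 log units; within the scatter) keeps compound 3 close, while a 4.3-fold lower number from compound 1 to compound 2 (0.64 log units; beyond the scatter) sets compound 2 clearly apart.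

Compound 4 `O=C1CC(Oc2ncccn2)CN1c1cnn2c1CN(C(=O)Nc1cc(F)c(F)c(F)c1)C(C1CC1)C2` changes only the group on the lactam ring: (pyrimidin-2-yl)oxy in place of 1,3-oxazol-5-yl on a saturated ring carbon. The step that bears most on this is a 1.2-fold lower number from compound 1 to compound 3 (0.08 log units; within the scatter), where the same position carried a different group with no change beyond the scatter; a 4.3-fold lower number from compound 1 to compound 2 (0.64 log units; beyond the scatter) removed the whole lactam and is less comparable. A step of about a 1.1-fold lower number from compound 1 to compound 4 (0.05 log units; within the scatter) is therefore expected, none beyond the scatter. Compound 4 is estimated at 125000 nM, between 60000 nM and 200000 nM.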

Compound 4, half-maximal cytotoxic concentration: > 200000 nM
Compound 4: only a limit was reported (the forecaster's own chance of this, stated with the estimate: 15%); middle value at least 1.6-fold (0.20 log units) from the limit.
By their numbers in this assay, from the lowest: compound 2; then compounds 3 and 1 (each within the scatter of the next). At a limit, above all of these: compound 4.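

Going from 1,3-oxazol-5-yl to (pyrimidin-2-yl)oxy on this saturated ring carbon gives an at least 1.4-fold higher number from compound 1 to compound 4 (0.15 log units; that floor lies within the scatter) in this assay. So this position accepts an aromatic ring attached through an oxygen, a six-membered ring in place of a five-membered one, without any fall in the number. Compound 4 reads only at a limit, so how far it really lies from compound 1 stays unknown: the limit of > 200000 nM in this assay, at which 1 of the 4 values shown sits.

On these data alone, whether an amine or a carboxylic acid on this carbon would keep the number this high remains open. So does whether a pyrimidin-2-yl group without the oxygen would behave like compound 4.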